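This account rests on a few compounds, and the source may have more. Where it says the series, first, only, none or still open, it means among the compounds named here.

Series notes.
- compound 1 `Nc1nc2[nH]c(CCSCC(=O)N[C@@H](CCC(=O)O)C(=O)O)cc2c(=O)[nH]1`: 373 nM in a functional assay on KB cells (Homo sapiens) for antiproliferative activity, read by MTT assay, with a stated time of 72 h, in the presence of a further agent that is not named here; on this read-out higher numbers stand for weaker inhibition and lower numbers for stronger inhibition
- compound 2 `Nc1nc2[nH]c(CCSCCC(=O)NCc3cccnc3)cc2c(=O)[nH]1`: 648 nM

Compound 1 holds the lower of the two numbers, but its gap to compound 2 lies within the scatter, so no order between them can be drawn. Compound 3 `Nc1nc2[nH]c(CCSCC(=O)NCc3cccnc3)cc2c(=O)[nH]1` is compound 1 with one change: (pyridin-3-yl)methyl in place of 1,3-dicarboxypropyl on an amide-type nitrogen. Among the measured compounds shown here, no measured pair isolates this change. Compound 2 also carries (pyridin-3-yl)methyl on an amide-type nitrogen and gives 648 nM. On that basis the expected step of a 1.6-fold higher number from compound 1 to compound 3 (0.21 log units; within the scatter) is small, if anything toward a higher number, and not beyond the scatter. Compound 3 is estimated at 600 nM, range 250 nM to 1500 nM.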

Compound 3, half-maximal inhibitory concentration: 37500 nM
Beside the measured number, compound 3's estimate is 63-fold (1.80 log units) below it; the whole stated range lies below it.
By their numbers in this assay, from the lowest: compounds 1 and 2 (each within the scatter of the next); then compound 3.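

On the amide-type nitrogen, the change to (pyridin-3-yl)methyl from 1,3-dicarboxypropyl is far from neutral in this assay: the number rises by a 100-fold higher number from compound 1 to compound 3 (2.00 log units; beyond the scatter). Compound 2 carries the same (pyridin-3-yl)methyl and gives 648 nM, so the presence of that group alone does not set the number. Nothing measured here accounts for the step.

Which part of the 1,3-dicarboxypropyl group matters remains open. A single carboxylic acid on a short chain at this nitrogen would help separate the contributions of its parts.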